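Trimming the side chain of a diarylthiourea benzimidazole

The compounds below may be only part of what the source reports. "The series", "measured", "known", "first", "only" and "open" are said of these compounds alone.

Going by the values given here, compound 3 `CC(C)C[C@@H](NC(=S)Nc1cc(C(F)(F)F)cc(C(F)(F)F)c1)c1nc2ccccc2[nH]1` gives 10200 nM in a functional assay on A549 cells (Homo sapiens) for cytotoxicity, read by MTT assay (a lower number here means a stronger inhibitor, a higher number a weaker inhibitor), the lowest of the three numbers measured so far. Compound 1 `CC(C)C[C@@H](NC(=S)Nc1ccccc1)c1nc2ccccc2[nH]1` gives 18700 nM, which lies within the scatter of compound 3, while compound 2 `CC(C)C[C@H](NC(=S)Nc1ccccc1)c1nc2ccccc2[nH]1` gives 28600 nM, beyond the scatter of compound 3. The only measured step between neighbours, a 1.5-fold higher number from compound 1 to compound 2 (0.18 log units; within the scatter), concerns a change of configuration alone, as shown by the fact that (the fact that compounds 1 and 2 differ only in the configuration as drawn); it says nothing about the size of the side chain.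

Compound 4 `C[C@@H](NC(=S)Nc1cc(C(F)(F)F)cc(C(F)(F)F)c1)c1nc2ccccc2[nH]1` differs from compound 3 by hydrogen in place of isopropyl on a saturated chain carbon, two bonds along the chain from an amide-type nitrogen and an aromatic carbon. Among the compounds with values here, no measured pair addresses such a shortening of the chain, so the expectation rests on compound 3 alone. He expects a modest weakening, a step of a 1.8-fold higher number from compound 3 to compound 4 (0.25 log units; within the scatter), but with wide uncertainty in either direction. His estimate for compound 4 is 18000 nM, within a range of 7000 nM to 50000 nM.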

Compound 4, half-maximal inhibitory concentration: 15200 nM
The estimate for compound 4 lay 1.2-fold (0.07 log units) above the measured number; the range from low to high includes it.
By their numbers in this assay, from the lowest: compounds 3, 4, 1 and 2 (each within the scatter of the next, the first and the last beyond it).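

In this assay, replacing isopropyl with hydrogen on this saturated chain carbon gives a step that stays within the scatter (a 1.5-fold higher number from compound 3 to compound 4 (0.17 log units; within the scatter)). The earlier step altered only the configuration, whereas this one alters the side chain itself and shows that cutting isobutyl to methyl, with the loss of three carbon atoms, leaves the number in the same range in this assay. Nothing at hand gives a reason for this step.

As far as these compounds go, it remains open whether a longer chain, a benzyl group, an amine or a carboxylic acid at this position would stay within the scatter or move the number beyond it. Also open, from the compounds shown here alone, is whether the same shortening would read alike in compound 1, with its unsubstituted phenyl ring.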